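Swapping a Triazole Substituent on a Smaller Core

The source may hold more compounds than are shown below. What is called first, only, known or untested is meant among the compounds shown, and "the series" means these compounds.

Compound 1 `CCCCCc1ccc(C#Cc2c(-c3ccc(CCCCC)cc3)oc3nc(=O)n(Cc4cn(-c5ccc(Cl)cc5)nn4)cc23)cc1` gives > 100000 nM in an ADME assay on WI-38 cells (Homo sapiens) for antiproliferative activity, read by MTT assay, with a stated time of 72 h (on this read-out higher numbers stand for weaker inhibition and lower numbers for stronger inhibition), a limit of the assay rather than a number.
Compound 2 `CCCCCc1ccc(C#Cc2c(-c3ccc(CCCCC)cc3)oc3nc(=O)n(Cc4cn(Cc5ccccc5)nn4)cc23)cc1` gives 2650 nM in this assay.
Compound 3 `O=c1nc2oc(C3CC3)cc2cn1Cc1cn(-c2ccc(Cl)cc2)nn1` gives > 100000 nM in this assay, again a limit of the assay rather than a number.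

Compound 1 and compound 2 differ in one place: benzyl in place of 4-chlorophenyl on an aromatic nitrogen. From the compounds shown here alone, that single change produced an at least 37-fold lower number from compound 1 to compound 2 (1.57 log units; beyond the scatter), a step that clearly stands out, although its true size is unknown because of the limit of > 100000 nM in this assay, at which 2 of the 3 values shown sit.

Compound 3 carries the same 4-chlorophenyl on the same kind of aromatic nitrogen, but its core is much smaller than that of compound 1; the difference between the two cores is not broken down here. The unmeasured compound 4 `O=c1nc2oc(C3CC3)cc2cn1Cc1cn(Cc2ccccc2)nn1` is related to compound 3 exactly as compound 2 is to compound 1: benzyl in place of 4-chlorophenyl on an aromatic nitrogen. Both "place" descriptions read the same word for word, so this is the same change, now on the smaller core.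

How far the step transfers is uncertain. Among the compounds with values here, for compound 4 an improvement is expected, an at least 2.5-fold lower number from compound 3 to compound 4 (0.39 log units; beyond the scatter), resting on the step seen from compound 1 to compound 2 in this assay, but a weaker one, since compound 3 has lost a large part of the molecule and no compound shows what the smaller core alone supports. The estimate for compound 4 in this assay is therefore 40000 nM, within 5000 nM to 100000 nM.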

Compound 4, half-maximal inhibitory concentration: 29700 nM
For compound 4 the middle estimate is 1.3-fold (0.13 log units) above the measured one; low and high end bracket the measured number.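

On the smaller core, benzyl in place of 4-chlorophenyl again lowers the number in this assay, with a step that lies beyond the usual scatter: an at least 3.3-fold lower number from compound 3 to compound 4 (0.52 log units; beyond the scatter). The direction of the change therefore carries over between these two cores, which is as far as two pairs of compounds can support, and it is no rule for other cores in the series. The size of the step is a different matter, since the starting compound of each pair gives only a limit of the assay and not a number, so neither step has a known true size and the two sizes cannot be ranked: the same change on two cores in this assay, an at least 37-fold lower number (1.57 log units; beyond the scatter) from compound 1 to compound 2 and an at least 3.3-fold lower number (0.52 log units; beyond the scatter) from compound 3 to compound 4; the limit leaves it open whether they differ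

The compounds shown leave open which part of the change matters, the loss of the chlorine or the extra carbon between the ring and the aromatic nitrogen, and a plain phenyl or a 4-chlorobenzyl group in the same place would separate the two. They also leave open whether the trend goes on with a longer chain, such as 2-phenylethyl, on that nitrogen.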